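A few compounds are considered here, and "the series" means these few. Any claim that something is new, unique, unknown or untested is made for them only; others in the source may bear on it.

Compound 1 `CCOC(=O)c1ccc(Nc2ccnc(SCC(=O)c3ccc([N+](=O)[O-])cc3)n2)cc1`: 13%
Compound 2 `COc1ccc(C(=O)CSc2nccc(Nc3cccc(C(C)=O)c3)n2)cc1`: 19%
Compound 3 `CC(=O)c1ccc(Nc2ccnc(SCC(=O)c3ccc(Br)cc3)n2)cc1`: 16%

Of the compounds shown here, three have so far been tested in a functional assay on NCI-H23 cells (Homo sapiens) for inhibition, read by sulforhodamine B assay, with a stated time of 48 h, tested at 10 uM; a lower number here means less inhibition of growth, a higher number more inhibition of growth at the concentration tested. Compound 1 gives 13%, compound 2 gives 19%, and compound 3 gives 16%. All three are weak at the concentration used, and the three numbers lie within the usual scatter of one another: compound 3 sits within the scatter of compound 1 and also within the scatter of compound 2, so none of the three can be told apart from the others, and none stands out as stronger or weaker.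

Compound 4 `CC(=O)c1ccc(Nc2ccnc(SCC(=O)c3ccc(Cl)cc3)n2)cc1` has not yet been measured. It differs from compound 3 in a single place: chloro in place of bromo on an aromatic carbon. Among the measured compounds shown here, no two measured compounds differ in only one place, so there is no measured step of any kind to lean on. The exchange of one halogen for another on the same aromatic carbon, para to a large group, is among the smallest changes a molecule can undergo, and the three measured numbers already sit close together. The expected step in this assay is therefore a number 1 percentage points lower from compound 3 to compound 4 (within the scatter), nothing beyond the scatter. For compound 4 the estimate in this assay is 15%, with a range from 4% to 26%.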

Compound 4, percent growth inhibition at one concentration: 13%
The estimate for compound 4 lay 2 percentage points above the measured number; the measured number falls inside the stated range.
By their numbers in this assay, from the lowest: compounds 1, 4, 3 and 2 (each within the scatter of the next).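

Among the compounds shown here, this is the first pair of compounds that differ in one place, and in this assay the step reads a number 3 percentage points lower from compound 3 to compound 4 (within the scatter) for chloro in place of bromo on an aromatic carbon, para to a large group. At this position, then, the two halogens cannot be told apart, so this pair gives no sign that the exchange matters for growth inhibition at the concentration tested, though it speaks for this one exchange on this one core only. No measurement at hand offers an explanation for this reading.

On these data alone, what stays open is whether a group of a very different kind on the same aromatic carbon, such as an amine or a carboxylic acid, would give a step beyond the scatter, since a swap of one halogen for another explores very little of what could sit there. Also open, as far as these compounds go, is whether a change elsewhere in the molecule, for example a longer chain in place of the acetyl group on the other aromatic ring, would separate any compound from this closely grouped set.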